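Trading Trimethylphenyl for Ethylphenyl on a Urea Nitrogen

The compounds below may be only part of what the source reports. "The series", "measured", "known", "first", "only" and "open" are said of these compounds alone.

Measured compounds:
compound 1, `CCCCCCCCCCCCCCCCCCNC(=O)Nc1c(OC)cc(OC)cc1OC`: 900 nM
compound 2, `CCCCCCCC/C=C\CCCCCCCCNC(=O)Nc1c(C)cc(C)cc1C`: 2900 nM

Both compounds were tested in an assay on microsomes from intestinal mucosa for inhibition of acyl-CoA:cholesterol acyltransferase (Oryctolagus cuniculus); a lower number here means a stronger inhibitor, a higher number a weaker inhibitor. Compound 1 gives 900 nM and compound 2 gives 2900 nM, so compound 2 stands as the higher of the two numbers, the weaker inhibitor here, and the gap between them lies beyond the usual scatter. Compound 3, `CCCCCCCC/C=C\CCCCCCCCNC(=O)Nc1ccccc1CC`, has not yet been measured in this assay. It differs from compound 2 in one place: 2-ethylphenyl in place of 2,4,6-trimethylphenyl on an amide-type nitrogen. Within the data shown here, nothing among the measured pair tells how this particular exchange plays out, since compound 1 and compound 2 differ in more than one place at once. The expectation is therefore cautious: a modest move toward a higher number, a 1.7-fold higher number from compound 2 to compound 3 (0.24 log units; within the scatter), is expected, possibly no larger than the scatter itself. Compound 3 is expected to give about 5000 nM, with a plausible range from 1500 nM to 15000 nM.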

Compound 3, half-maximal inhibitory concentration: 980 nM
Compound 3: the middle estimate sits 5.1-fold (0.71 log units) above what was measured; the whole stated range lies above it.
By their numbers in this assay, from the lowest: compounds 1 and 3 (each within the scatter of the next); then compound 2.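

In this assay the exchange of 2,4,6-trimethylphenyl for 2-ethylphenyl on an amide-type nitrogen brings a 3.0-fold lower number from compound 2 to compound 3 (0.47 log units; beyond the scatter) and so shows that the group at this position can change the result by more than the usual scatter. It also shows that 2,4,6-trimethylphenyl is not needed for inhibition in this series, since the exchange gives a stronger inhibitor, not a weaker one. Nothing at hand explains why this exchange lowers the number.

Because the exchange alters the ring in more than one way, the compounds shown cannot separate the gain of the ethyl group from the loss of the methyl groups. A plain phenyl or a 2-methylphenyl at this position would help to pull those two changes apart, and a 2-isopropylphenyl would show whether a larger alkyl group continues the trend.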